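The source may hold more compounds than are shown below. What is called first, only, known or untested is meant among the compounds shown, and "the series" means these compounds.

The measured compounds and their values:

Compound 1, `Cc1ccc(OCC(=O)N(Cc2cccs2)c2ccn(C)n2)cc1`: 855 nM
Compound 2, `CCN(Cc1ccoc1)C(=O)COc1ccc(C)cc1`: 136 nM
Compound 3, `CCN(Cc1cccs1)C(=O)COc1ccc(C(F)(F)F)cc1`: 236 nM

All three were tested in an assay on HEK293 cells for agonist activity at transient receptor potential cation channel subfamily M member 8 (Homo sapiens), read by fluorescence and calcium flux, with a stated time of 15 min; a higher number here means that more compound is needed for the effect, a lower number that less compound is needed. Among these three numbers, compound 2 has the lowest. The nearest to it is compound 3, whose value lies within the usual scatter of this assay, so the two cannot be told apart. The furthest is compound 1, whose value lies beyond the scatter, so compound 2 needs clearly less compound than compound 1 for the same effect.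

The next compound, compound 4, is `CCN(Cc1ccco1)C(=O)COc1ccc(C)cc1`. It is built from the same atoms as compound 2, joined differently: furan-2-yl in place of furan-3-yl on a saturated chain carbon bound to an amide-type nitrogen. Read one bond further out, the change is from a (furan-3-yl)methyl to a (furan-2-yl)methyl group on the amide nitrogen.

Among the compounds with values here, no measured pair shows this exact swap, so the size of the step must be guessed. The two ring types are closely alike. A step of no more than the usual scatter, in either direction, seems most plausible. Compound 4 is therefore expected to give about 160 nM, with a likely range from 55 nM to 480 nM. This estimate means a step of a 1.2-fold higher number from compound 2 to compound 4 (0.07 log units; within the scatter), which is expected to stay within the scatter.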

Compound 4, half-maximal effective concentration: 489 nM
Compound 4: the middle estimate sits 3.1-fold (0.49 log units) below what was measured; the whole stated range lies below it.
By their numbers in this assay, from the lowest: compounds 2 and 3 (each within the scatter of the next); then compounds 4 and 1 (each within the scatter of the next).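

In this assay, replacing furan-3-yl with furan-2-yl on a saturated chain carbon bound to an amide-type nitrogen gives a 3.6-fold higher number from compound 2 to compound 4 (0.56 log units; beyond the scatter), so this position responds to the point at which the furan ring is attached and not only to which ring is present. The group that leaves and the group that enters have the same heavy atoms, the same ring size and the same counts of hydrogen-bond donors and acceptors, so those counts alone do not capture a difference that matters in this pair. Nothing available here explains why the two attachment points give different numbers.

This single pair cannot show whether the furan-3-yl group holds any special place at this position, or whether a phenyl or pyridin-3-yl group on the same carbon would give a lower or a higher number. It also leaves open whether the same furan swap would give a step of similar size with a trifluoromethyl group in place of the methyl group on the other aromatic ring, or with a propyl group in place of the ethyl group on the amide nitrogen.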